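Triazole in Place of Thiazolidinedione on the Side Chain

The compounds below may be only part of what the source reports. "The series", "measured", "known", "first", "only" and "open" are said of these compounds alone.

Compound 1 `O=C1O[C@@H](CO)CN1c1ccc(-n2cc(-c3ccccn3)cn2)c(F)c1` gives 59 ug/mL in an ADME assay on L02 cells (Homo sapiens) for cytotoxicity, read by MTT assay, with a stated time of 48 h (on this read-out higher numbers stand for weaker inhibition and lower numbers for stronger inhibition), and compound 2 `CCN1CCN(C[C@H]2CN(c3ccc(-n4cc(-c5ccccn5)cn4)c(F)c3)C(=O)O2)CC1` gives 99 ug/mL in this assay. Compound 3 `O=C1CSC(=O)N1C[C@H]1CN(c2ccc(-n3cc(-c4ccccn4)cn3)c(F)c2)C(=O)O1` reaches only a limit of this assay, > 400 ug/mL, so no number is known for it (the limit of > 400 ug/mL in this assay, at which 1 of the 3 values shown sits). The step of a 1.7-fold higher number from compound 1 to compound 2 (0.22 log units; within the scatter) lies within the scatter, whereas an at least 6.7-fold higher number from compound 1 to compound 3 (0.83 log units; beyond the scatter) and an at least 4.0-fold higher number from compound 2 to compound 3 (0.60 log units; beyond the scatter) are each at least modest.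

Compound 4 `O=C1O[C@@H](Cn2ccnn2)CN1c1ccc(-n2cc(-c3ccccn3)cn2)c(F)c1` carries 1H-1,2,3-triazol-1-yl in place of 2,4-dioxo-1,3-thiazolidin-3-yl on a saturated chain carbon bound to a saturated ring carbon. Going by the values given here, no measured step places a triazole at this position; the nearest guides are the two steps that bring in 2,4-dioxo-1,3-thiazolidin-3-yl, which run past the limit, and the step to 4-ethylpiperazin-1-yl, which stays within the scatter of compound 1. A ring on this chain carbon therefore spans the whole range seen so far. The step of an at least 2.6-fold lower number from compound 3 to compound 4 (0.42 log units; beyond the scatter) is expected to read as a return from the limit into measurable numbers, with no firm size attached. Compound 4 is estimated at 150 ug/mL, between 50 ug/mL and 400 ug/mL, with a real chance that this assay again reports only a limit.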

Compound 4, half-maximal inhibitory concentration: 49 ug/mL
Beside the measured number, compound 4's estimate is 3.1-fold (0.49 log units) above it; measured number outside the range, below it.
By their numbers in this assay, from the lowest: compounds 4, 1 and 2 (each within the scatter of the next, the first and the last beyond it). At a limit, above all of these: compound 3.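

In this assay 1H-1,2,3-triazol-1-yl on a saturated chain carbon bound to a saturated ring carbon gives an at least 8.1-fold lower number from compound 3 to compound 4 (0.91 log units; beyond the scatter) and so shows that a five-membered ring at this place does not by itself carry the reading to the limit. The same group gives a 2.0-fold lower number from compound 2 to compound 4 (0.31 log units; beyond the scatter) against 4-ethylpiperazin-1-yl, a modest step, while a 1.2-fold lower number from compound 1 to compound 4 (0.08 log units; within the scatter) leaves it indistinguishable from hydroxy. Compound 3 alone remains at a limit, which is not a number: the limit of > 400 ug/mL in this assay, at which 1 of the 4 values shown sits.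

Which part of 2,4-dioxo-1,3-thiazolidin-3-yl goes with that limit, the sulfur or the double bonds outside aromatic rings, stays open. Going by these compounds, how a carboxylic acid, a primary amine or a longer chain on this carbon would read in this assay also stays open.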